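One five-membered ring exchanged, lipophilicity still open

A few compounds are considered here, and "the series" means these few. Any claim that something is new, unique, unknown or untested is made for them only; others in the source may bear on it.

In a physicochemical assay for lipophilicity (on this read-out lower numbers stand for lower lipophilicity and higher numbers for higher lipophilicity), compound 2 `Cc1nc(-c2cc(C(F)(F)F)ccc2[C@@H]2CCOc3cc(S(=O)(=O)Nc4nccs4)ccc32)co1` stands highest of three measured compounds (2.9). Compound 3 `Cn1nccc1-c1cc(C(F)(F)F)ccc1[C@H]1CCc2cc(S(=O)(=O)Nc3ncccn3)ccc21` lies lower (2.4) and compound 1 `CN1CCN(c2cc(C(F)(F)F)ccc2[C@H]2CCOc3cc(S(=O)(=O)Nc4nccs4)ccc32)CC1` lower still (2.1), both gaps to compound 2 being beyond the scatter.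

Compound 4 `Cn1nccc1-c1cc(C(F)(F)F)ccc1[C@@H]1CCOc2cc(S(=O)(=O)Nc3nccs3)ccc21` has not been measured. It keeps the core of compound 2 but has 1-methyl-1H-pyrazol-5-yl in place of 2-methyl-1,3-oxazol-4-yl on an aromatic carbon. Among the compounds with values here, no measured pair isolates this exchange. Compound 3 carries the same 1-methyl-1H-pyrazol-5-yl on a different core (2.4), which offers only a loose hint.

The estimated step is small, downward and no larger than the scatter (a number 0.20 log units lower from compound 2 to compound 4 (within the scatter)). For compound 4 the expected value is 2.7 (estimated range 2.3 to 3.1).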

Compound 4, distribution coefficient: 2.2
Compound 4: the middle estimate sits 0.50 log units above what was measured, outside the stated range (below it).
By their numbers in this assay, from the lowest: compounds 1, 4 and 3 (each within the scatter of the next); then compound 2.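

In this assay, putting 1-methyl-1H-pyrazol-5-yl in place of 2-methyl-1,3-oxazol-4-yl on this aromatic carbon gives a number 0.70 log units lower from compound 2 to compound 4 (beyond the scatter), so the read-out clearly separates these two groups. The groups match in heavy atoms, hydrogen-bond donors, hydrogen-bond acceptors and net charge, so those counts alone do not tell them apart here. Nothing available explains the size of this step.

On these data alone, whether the same exchange gives a similar step on another core remains open. So does how a carboxylic acid or a nitrile on this aromatic carbon would compare.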